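The compounds below may be only part of what the source reports. "The series", "measured", "known", "first", "only" and "open" are said of these compounds alone.

Working notes on the series. Compound 1 `Cc1ccccc1Nc1nc(Nc2ccccn2)ncc1Cl` and compound 2 `COc1cccc(CNc2nc(Nc3ccc(N4CCN(C)CC4)cn3)ncc2Cl)c1` have both been run in an ADME assay on L02 cells (Homo sapiens) for inhibition, read by CCK-8 assay, with a stated time of 48 h; a lower number here means a stronger inhibitor of growth, a higher number a weaker inhibitor of growth; compound 1 gives 6150 nM and compound 2 gives 16200 nM. For the measured compounds named here, compound 2 therefore holds the higher of the two numbers so far, and the gap between these two values lies beyond the usual scatter of the assay. Compound 3 `COc1ccc(Nc2nc(Nc3ccc(N4CCN(C)CC4)cn3)ncc2Cl)cc1` has not yet been measured. The change from compound 2 to compound 3 is 4-methoxyphenyl in place of 3-methoxybenzyl on a nitrogen on an aromatic ring. Going by the values given here, no single-change pair has been measured that would calibrate this step directly, so only the two values give any bearing: compound 1, which also carries a phenyl-type group on the ring nitrogen, gives 6150 nM, the lower value. On that basis a modest step toward a lower number is expected, a 1.8-fold lower number from compound 2 to compound 3 (0.26 log units; within the scatter), with the caution that the measured pair differs in more than one place. For compound 3 the estimated value in this assay is 9000 nM, with a range from 3000 nM to 30000 nM.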

Compound 3, concentration for 50% growth inhibition: 3150 nM
Compound 3: middle estimate off by 2.9-fold (0.46 log units), on the high side; the measured number falls inside the stated range.
By their numbers in this assay, from the lowest: compounds 3 and 1 (each within the scatter of the next); then compound 2.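

In this assay, for the compounds shown here, the first single-place comparison is now available: (4-methoxyphenyl)amino in place of (3-methoxybenzyl)amino gives a 5.1-fold lower number from compound 2 to compound 3 (0.71 log units; beyond the scatter). This shows that the group on this nitrogen can shift the number beyond the scatter while the rest of compound 3 stays as in compound 2. No measured evidence accounts for the size or direction of this step.

The step combines a change from benzyl to phenyl with a change from a 3-methoxy to a 4-methoxy group, and these two compounds cannot separate the two contributions. Going by these compounds, a 3-methoxyphenyl or a 4-methoxybenzyl group on the same nitrogen would divide the step into its two parts, and whether an unsubstituted phenyl behaves like 4-methoxyphenyl remains open.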